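Fluoro for methoxy on the pendant phenyl ring

A few compounds are considered here, and "the series" means these few. Any claim that something is new, unique, unknown or untested is made for them only; others in the source may bear on it.

The series shares one core, carried by compound 1 `c1ccc(-c2cn3ccnc3c(-c3ccc4ncn(C5CCCCC5)c4c3)n2)cc1`, which in a functional assay on NCI-H522 cells (Homo sapiens) for inhibition, read by sulforhodamine B assay, with a stated time of 48 h, tested at 10 uM (a lower number here means less inhibition, a higher number more inhibition at the concentration tested (going by the name of the read-out)), gives 58.1%. Compound 2 `COc1ccc(-c2cn3ccnc3c(-c3ccc4ncn(C5CCCCC5)c4c3)n2)cc1` stands lowest of the three measured compounds, giving -20.9% in this assay, while compound 3 `O=Cc1ccc(-c2cn3ccnc3c(-c3ccc4ncn(C5CCCCC5)c4c3)n2)cc1` gives 25.3%. The measured steps show a number 79 percentage points lower from compound 1 to compound 2 (beyond the scatter) and a number 46.2 percentage points higher from compound 2 to compound 3 (beyond the scatter), both beyond the scatter, and a number 32.8 percentage points lower from compound 1 to compound 3 (beyond the scatter).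

Compound 4 `Fc1ccc(-c2cn3ccnc3c(-c3ccc4ncn(C5CCCCC5)c4c3)n2)cc1` has not been measured. It differs from compound 2 by fluoro in place of methoxy on an aromatic carbon. Going by the values given here, two steps bear on this change: the one in which methoxy replaced hydrogen, from compound 1 to compound 2, was large and downward, and the one in which formyl replaced methoxy, from compound 2 to compound 3, was large and upward. Both show that removing the methoxy from this position is accompanied by a large rise in this assay, so a rise beyond the scatter is expected for compound 4 too, though no direct comparison with fluoro exists. The expected step is a number 55.9 percentage points higher from compound 2 to compound 4 (beyond the scatter).

Compound 4 is therefore estimated to give 35% in this assay, within a range from 0% to 65%.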

Compound 4, a percentage reported as inhibition, at one concentration (the size of the read-out at that concentration, not a potency): 15.5%
Estimate against measurement, compound 4: 19.5 percentage points above; measured number inside the range.
By their numbers in this assay, from the lowest: compound 2; then compounds 4 and 3 (each within the scatter of the next); then compound 1.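

In this assay, the change from methoxy to fluoro brings a large rise (a number 36.4 percentage points higher from compound 2 to compound 4 (beyond the scatter)), but this recovers only part of what the methoxy step lost, as the unsubstituted compound remains clearly separate (a number 42.6 percentage points lower from compound 1 to compound 4 (beyond the scatter)). So removing the methoxy does not by itself restore the level of compound 1: fluoro, a single atom, also lies well short of hydrogen at this position, and all three groups shown there give lower numbers than hydrogen, with no compound going against this. Fluoro and formyl cannot be told apart here (a number 9.8 percentage points lower from compound 3 to compound 4 (within the scatter)), even though they are quite different groups, and nothing available explains why any of these groups gives the number it does.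

From the compounds shown here alone, whether an amine, a carboxylic acid or a simple methyl at this position would fall with fluoro and formyl, or come closer to hydrogen, remains open. Also open, going by these compounds, is whether the same ranking would hold at other concentrations, since each compound is represented here by a reading at one concentration in one cell line.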